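Dichlorophenyl swap on a shared amide core

A few compounds are considered here, and "the series" means these few. Any claim that something is new, unique, unknown or untested is made for them only; others in the source may bear on it.

Compound 1 `CC(Sc1nnc(-c2ccncc2)s1)C(=O)Nc1ccc(Cl)cc1Cl` gives > 50000 nM in an ADME assay on HepG2 cells (Homo sapiens) for cytotoxicity, with a stated time of 3 days; a higher number here means that more compound is tolerated, a lower number that less compound is tolerated.
Compound 2 `CC(Sc1nnc(-c2ccncc2)s1)C(=O)Nc1c(Cl)cccc1Cl` gives > 50000 nM in this assay.
Compound 3 `CC(CSc1nnc(-c2ccncc2)s1)C(=O)Nc1c(Cl)cccc1Cl` gives > 50000 nM in this assay.

Each of these values is a limit of this assay and not a number; all three sit at the limit of > 50000 nM in this assay, at which 3 of the 3 values shown sit. The change from compound 2 to compound 1 is 2,4-dichlorophenyl in place of 2,6-dichlorophenyl on an amide-type nitrogen, and the step that the two limits leave unreadable from compound 2 to compound 1 is one that the two limits leave unreadable. How the core of compound 2 differs from the core of compound 3 is not broken down here. Compound 4 `CC(CSc1nnc(-c2ccncc2)s1)C(=O)Nc1ccc(Cl)cc1Cl` has not yet been measured in this assay; it differs from compound 3 by 2,4-dichlorophenyl in place of 2,6-dichlorophenyl on an amide-type nitrogen, the same change as that from compound 2 to compound 1. The expectation rests on compound 3, which gives > 50000 nM. It also rests on the unreadable step that the two limits leave unreadable from compound 2 to compound 1. For compound 4 the expected step of a number no higher from compound 3 to compound 4 (the limit leaves the size open) is estimated to be essentially none. Compound 4 is therefore expected at 50000 nM, between 30000 nM and 100000 nM.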

Compound 4, half-maximal cytotoxic concentration: > 50000 nM
Compound 4 gave a limit, no number (the forecaster's own chance of this, stated with the estimate: 85%); the middle value sits exactly at the limit.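

Compound 3 and compound 4 both give a limit rather than a number in this assay, so no step can be read between them: the limit of > 50000 nM in this assay, at which 4 of the 4 values shown sit.

The compounds shown leave open at what concentration any of them becomes cytotoxic, and whether 2,4-dichlorophenyl in place of 2,6-dichlorophenyl alters that concentration.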